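The source may hold more compounds than are shown below. What is called first, only, known or untested is meant among the compounds shown, and "the series" means these compounds.

Measured so far in an assay (Rattus norvegicus) for inhibition of Fatty-acid amide hydrolase 1 (Homo sapiens); on this read-out lower numbers stand for stronger inhibition and higher numbers for weaker inhibition:
compound 1 `O=C(CCCCCCc1ccccc1)c1ncc(-c2ccc([N+](=O)[O-])cc2)o1` gives 50 nM;
compound 2 `NC(=O)c1ccc(-c2cnc(C(=O)CCCCCCc3ccccc3)o2)cc1` gives 10 nM.

Compound 2 holds the lower of the two numbers in this assay; the step of a 5.0-fold lower number from compound 1 to compound 2 (0.70 log units; beyond the scatter) separates it from compound 1 and lies beyond the scatter. Compound 3 `O=C(CCCCCCc1ccccc1)c1ncc(-c2ccc(C(=O)C(F)(F)F)cc2)o1` differs from compound 2 by trifluoromethyl in place of amino on a carbonyl carbon. No measured step touches a carbonyl carbon, so nothing shown bears on this change; the only step known, from compound 1 to compound 2, concerns another part of the molecule. Compound 3 is therefore expected to sit close to compound 2, with a step of a 1.5-fold higher number from compound 2 to compound 3 (0.18 log units; within the scatter) that stays within the scatter, and an estimated 15 nM in this assay, between 4 nM and 60 nM.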

Compound 3, inhibition constant: 65 nM
For compound 3 the middle estimate is 4.3-fold (0.64 log units) below the measured one; measured number above the stated range.
By their numbers in this assay, from the lowest: compound 2; then compounds 1 and 3 (each within the scatter of the next).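

In this assay the carbonyl carbon proves sensitive to what it carries: the result is a 6.5-fold higher number from compound 2 to compound 3 (0.81 log units; beyond the scatter) when trifluoromethyl replaces amino. The (trifluoromethyl)carbonyl group in place of nitro gives a 1.3-fold higher number from compound 1 to compound 3 (0.11 log units; within the scatter), so among these three groups on the aromatic carbon only carbamoyl separates its compound from the others. No evidence is available to explain this difference.

Going by these compounds, it remains open whether a carboxylic acid, a nitrile or a methyl ketone on this aromatic carbon would stand with carbamoyl or with the other two groups. On these data alone, it is also open whether an N-methyl amide would keep the number of compound 2.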